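The compounds below may be only part of what the source reports. "The series", "measured", "known", "first", "only" and "open" are said of these compounds alone.

Measured compounds:
compound 1 `COc1cc(NC(C)CCCN2C(=O)CN(C(=O)[C@@H](C)N)C2(C)C)c2ncccc2c1` — > 3 h
compound 2 `COc1cc(NC(C)CCCN2C(=O)CNC2(C)C)c2ncccc2c1` — > 3 h

In an ADME assay on a cell-free system (plasma, Homo sapiens) for metabolic stability, with Plasma (Rattus norvegicus) as the target, read by HPLC (on this read-out higher numbers stand for a longer-lived compound and lower numbers for a shorter-lived compound), compound 1 reaches only the limit of the assay, > 3 h. For compound 2 this assay likewise reports only a limit, > 3 h. Where compound 2 stands is thus known only as a limit, and the one further value shown, that of compound 1, is a limit too. The step that the two limits leave unreadable from compound 1 to compound 2 cannot be read because both of its values sit at the limit of > 3 h in this assay, at which 2 of the 2 values shown sit.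

Compound 3 `COc1cc(NC(C)CCCN2C(=O)CN(C(=O)CN)C2(C)C)c2ncccc2c1` differs from compound 2 by (aminomethyl)carbonyl in place of hydrogen on an amine nitrogen in a ring. Among the compounds with values here, the only measured step that bears on this change is the unreadable one just described, so no size or direction can be taken from it. Compound 3 is therefore expected to sit at the same limit as the two measured compounds. Its estimated value in this assay is 4 h, with a range from 2 h to 10 h. The step expected for compound 3 is a step that the limit leaves unreadable from compound 2 to compound 3, none beyond the scatter.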

Compound 3, half-life: > 3 h
Compound 3 gave a limit, no number (the forecaster's own chance of this, stated with the estimate: 75%); the middle value lies beyond the limit too.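

In this assay no new step can be read among compound 1, compound 2 and compound 3, because each of them gives only a limit: the limit of > 3 h in this assay, at which 3 of the 3 values shown sit.

The compounds shown leave open how long any of the three lasts past that limit, and whether (aminomethyl)carbonyl in place of hydrogen on the amine nitrogen in a ring changes the half-life at all.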